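Chlorinated purine series: cytotoxicity working notes

The source may hold more compounds than are shown below. What is called first, only, known or untested is meant among the compounds shown, and "the series" means these compounds.

Measured compounds:
- compound 1 `ClCc1cccc(Cn2cnc3c(Cl)ncnc32)c1`; in a functional assay on NCI-H460 cells (Homo sapiens) for cytotoxicity, read by sulforhodamine B assay, with a stated time of 48 h (on this read-out lower numbers stand for higher toxicity in this test and higher numbers for lower toxicity in this test), compound 1 sits at the limit > 100000 nM, a limit and not a number.
- compound 2 `ClCc1cccc(Cn2cnc3c(Cl)nc(Cl)nc32)c1`; in this assay compound 2 sits at the limit > 100000 nM, again a limit.
- compound 3 `ClCc1ccccc1Cn1cnc2ncnc(Cl)c21`; in this assay compound 3 sits at the limit > 100000 nM, also a limit.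

Compound 2 differs from compound 1 by chloro in place of hydrogen on an aromatic carbon. The resulting step, a step that the two limits leave unreadable from compound 1 to compound 2, cannot be read because of the limit of > 100000 nM in this assay, at which 3 of the 3 values shown sit. Compound 3 and compound 1 are built from the same atoms joined differently; the difference between the two cores is not broken down here.

Compound 4 `ClCc1ccccc1Cn1cnc2nc(Cl)nc(Cl)c21` is not yet measured. It differs from compound 3 by chloro in place of hydrogen on an aromatic carbon, the same change as from compound 1 to compound 2. Since compound 3 shows only a limit in this assay, the step is expected to be a number no higher from compound 3 to compound 4 (the limit leaves the size open) and likewise unreadable. For compound 4 the expected value is 100000 nM, with a range from 40000 nM to 300000 nM, most probably reported as a limit.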

Compound 4, concentration lethal to 50% of the cells: > 100000 nM
Compound 4: no number, only a limit; the forecaster's own chance of this, stated with the estimate: 85%; the middle value lies on the limit itself.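

No step can be read from compound 3 to compound 4, because both are limits and not numbers: (the limit of > 100000 nM in this assay, at which 4 of the 4 values shown sit). The compounds shown leave open whether chloro in place of hydrogen on an aromatic carbon changes cytotoxicity at all.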